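A naphthyl arm in place of the formylphenyl

The source may hold more compounds than are shown below. What is called first, only, known or untested is meant among the compounds shown, and "the series" means these compounds.

Three compounds share one core and differ only in the group on an aromatic carbon of that core. Compound 1 `Brc1cn2ccnc2c(-c2ccc3ncn(C4CCCCC4)c3c2)n1` carries a bromo there, and in a functional assay on HCT-15 cells (Homo sapiens) for inhibition, read by sulforhodamine B assay, with a stated time of 48 h, tested at 10 uM (a higher number here means more inhibition at the concentration tested (going by the name of the read-out), a lower number less inhibition), compound 1 gives 13.1%. Compound 2 `COc1ccc(-c2cn3ccnc3c(-c3ccc4ncn(C5CCCCC5)c4c3)n2)cc1` carries a 4-methoxyphenyl, and in this assay compound 2 gives 78.8%. Compound 3 `O=Cc1ccc(-c2cn3ccnc3c(-c3ccc4ncn(C5CCCCC5)c4c3)n2)cc1` carries a 4-formylphenyl, and in this assay compound 3 gives 49.1%, the second highest of the three, with compound 2 higher and compound 1 lower.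

Compound 4 `c1ccc2c(-c3cn4ccnc4c(-c4ccc5ncn(C6CCCCC6)c5c4)n3)cccc2c1` has not yet been measured. The change is naphthalen-1-yl in place of 4-formylphenyl on an aromatic carbon. Two kinds of step bear on it. Putting an aryl group in place of bromo raised inhibition strongly: a number 65.7 percentage points higher from compound 1 to compound 2 (beyond the scatter) and a number 36 percentage points higher from compound 1 to compound 3 (beyond the scatter). Exchanging one substituent for another within that aryl mattered less: a number 29.7 percentage points lower from compound 2 to compound 3 (beyond the scatter). Because compound 3 gives 49.1% and compound 2 gives 78.8% with an aryl in place, compound 4 is expected to stay well above compound 1. The expected step is modest, a number 5.9 percentage points higher from compound 3 to compound 4 (within the scatter). Compound 4 is estimated at 55%, within 30% to 80%.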

Compound 4, a percentage reported as inhibition, at one concentration (the size of the read-out at that concentration, not a potency): 4.46%
Compound 4: middle estimate off by 50.5 percentage points, on the high side; the whole stated range lies above it.
By their numbers in this assay, from the lowest: compounds 4 and 1 (each within the scatter of the next); then compound 3; then compound 2.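

In this assay, this position does not reward every aromatic arm: naphthalen-1-yl gives a large loss against both phenyl arms (a number 44.6 percentage points lower from compound 3 to compound 4 (beyond the scatter); a number 74.3 percentage points lower from compound 2 to compound 4 (beyond the scatter)), so the gain seen with 4-methoxyphenyl and 4-formylphenyl does not extend to this group with its two aromatic rings. Against the bromo of compound 1 the step lies within the scatter (a number 8.6 percentage points lower from compound 1 to compound 4 (within the scatter)), which leaves compound 4 and compound 1 indistinguishable in this read-out despite the much larger group now in place. No measured evidence accompanies this result, so the loss remains unexplained.

The compounds shown leave open whether an unsubstituted phenyl or naphthalen-2-yl would retain inhibition or lose it as compound 4 does. They also leave open how an amine or a carboxylic acid at the 4-position of the phenyl would compare with the methoxy and formyl groups.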